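The source may hold more compounds than are shown below. What is called first, only, known or untested is meant among the compounds shown, and "the series" means these compounds.

Measured compounds:
compound 1, `[N-]=[N+]=NCc1nnc(-c2cc(S(N)(=O)=O)c(SCc3ccccc3)cc2Cl)o1` — 115000 nM
compound 2, `NS(=O)(=O)c1cc(-c2nnc(/C=C/c3cccc(Cl)c3)o2)c(Cl)cc1SCc1ccccc1` — 16000 nM

In a functional assay on HeLa cells (Homo sapiens) for cytotoxicity, read by MTT assay, with a stated time of 72 h (on this read-out lower numbers stand for stronger inhibition and higher numbers for weaker inhibition), compound 2 holds the lowest of the two numbers; its nearest neighbour is compound 1, and the step of a 7.2-fold lower number from compound 1 to compound 2 (0.86 log units; beyond the scatter) lies beyond the scatter. Compound 3, `NS(=O)(=O)c1cc(-c2nnc(/C=C/c3ccc(Cl)cc3)o2)c(Cl)cc1SCc1ccccc1`, differs from compound 2 by 4-chlorophenyl in place of 3-chlorophenyl on a double-bonded chain carbon bound to a double-bonded chain carbon. Among the measured compounds shown here, no measured step shifts a chlorine around a phenyl ring, so the only step known, a 7.2-fold lower number from compound 1 to compound 2 (0.86 log units; beyond the scatter), concerns a different change and does not bear on this one. Compound 3 is therefore expected to stay close to compound 2, with a step of no change at the digits printed from compound 2 to compound 3 (within the scatter) not beyond the scatter. The estimate for compound 3 is 16000 nM, within 6000 nM to 45000 nM.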

Compound 3, half-maximal inhibitory concentration: 40000 nM
The estimate for compound 3 lay 2.5-fold (0.40 log units) below the measured number, and the stated range covers the measured number.
By their numbers in this assay, from the lowest: compound 2; then compound 3; then compound 1.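

In this assay the chlorine's place on the phenyl ring is not neutral: 4-chlorophenyl in place of 3-chlorophenyl gives a 2.5-fold higher number from compound 2 to compound 3 (0.40 log units; beyond the scatter) and so gives back part of the gain seen over azidomethyl. That gain survives the change, with a 2.9-fold lower number from compound 1 to compound 3 (0.46 log units; beyond the scatter) still printed as beyond the scatter, so both chlorophenyl ethenyl compounds stand lower than the azidomethyl compound. No evidence at hand explains the difference between the two chlorine placements.

The compounds shown leave open where 2-chlorophenyl or an unsubstituted phenyl would fall on the same ethenyl chain, and whether a methoxy group would follow chlorine.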